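The source may hold more compounds than are shown below. What is called first, only, known or untested is meant among the compounds shown, and "the series" means these compounds.

Compound 2 `COc1ccccc1C1=NN(C(=S)Nc2ccccc2)C(c2ccc3c(c2)OCCO3)C1` gives in a functional assay on HT-29 cells (Homo sapiens) for antiproliferative activity, read by MTT assay, with a stated time of 48 h (on this read-out higher numbers stand for weaker inhibition of growth and lower numbers for stronger inhibition of growth), a value of 30500 nM, which stands as the larger of the two numbers measured, though only within the scatter of compound 1 `Cc1ccc(C2=NN(C(=S)Nc3ccccc3)C(c3ccc4c(c3)OCCO4)C2)cc1`, which gives 19500 nM. That step, a 1.6-fold higher number from compound 1 to compound 2 (0.19 log units; within the scatter), exchanged one aryl group on the carbon with a double bond to nitrogen for another without a change beyond the scatter. Compound 3 `S=C(Nc1ccccc1)N1N=C(c2ccc(Cl)c(Cl)c2)CC1c1ccc2c(c1)OCCO2` carries the change (3,4-dichlorophenyl in place of 2-methoxyphenyl on a carbon with a double bond to nitrogen). Within the data shown here, since the one aryl exchange seen so far moved little, the step of a 2.0-fold lower number from compound 2 to compound 3 (0.31 log units; beyond the scatter) is expected to be small, and compound 3 is estimated at 15000 nM, within 4000 nM to 60000 nM.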

Compound 3, concentration for 50% growth inhibition: 95300 nM
Estimate against measurement, compound 3: 6.4-fold (0.80 log units) below, outside the stated range (above it).
By their numbers in this assay, from the lowest: compounds 1 and 2 (each within the scatter of the next); then compound 3.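

In this assay the 3,4-dichlorophenyl group brings a 3.1-fold higher number from compound 2 to compound 3 (0.49 log units; beyond the scatter) and a 4.9-fold higher number from compound 1 to compound 3 (0.69 log units; beyond the scatter), so growth inhibition is weaker with this group than with either earlier aryl group. The position on the carbon with a double bond to nitrogen therefore does respond to the choice of aryl group, which the earlier exchange, within the scatter, did not show. Nothing at hand explains this change. Going by these compounds, it remains open whether both chlorine atoms are needed for the shift, as a 4-chlorophenyl group could show. On these data alone, how a group other than an aryl ring, such as an amine or a carboxylic acid, would read at this place also remains open.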